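This account rests on a few compounds, and the source may have more. Where it says the series, first, only, none or still open, it means among the compounds named here.

Measured compounds, with their numbers in a functional assay on MGC-803 cells (Homo sapiens) for antiproliferative activity, read by CCK-8 assay, with a stated time of 72 h, tested at 2 uM; a higher number here means a stronger effect of the compound at the concentration tested, a lower number a weaker effect:

compound 1, `Nc1ccccc1NC(=O)c1ccc(CSC(=S)N2CCN(Cc3ccccn3)CC2)cc1`: 23.4%
compound 2, `Nc1ccccc1NC(=O)c1ccc(CSC(=S)N2CCN(C(c3ccccc3)c3ccccc3)CC2)cc1`: 9.8%
compound 3, `Nc1ccccc1NC(=O)c1ccc(CSC(=S)N2CCN(c3ccc(Cl)cc3)CC2)cc1`: 15%

Compound 3 lies between the other two numbers in this assay; its gap to compound 2 and its gap to compound 1 are both within the scatter, so no order among the three can be claimed. Going by the values given here, the only measured step that changes one place is a number 8.4 percentage points lower from compound 1 to compound 3 (within the scatter), which swaps the whole group on the amine nitrogen in the ring and is itself within the scatter. Compound 4, `Nc1ccccc1NC(=O)c1ccc(CSC(=S)N2CCN(c3ccccc3)CC2)cc1`, is not yet measured. Among the compounds with values here, it differs from compound 3 by hydrogen in place of chloro on an aromatic carbon; no measured pair in this set touches the para position of that aryl group, so the step from compound 1 to compound 3 bears on it only loosely. With the entire series spread within the scatter in this assay, no step beyond the scatter is expected in either direction for this change. The estimated step is a number 2 percentage points lower from compound 3 to compound 4 (within the scatter), meaning compound 4 is expected at about 13% in this assay, with a range from 3% to 25%.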

Compound 4, a percentage reported as inhibition, at one concentration (the size of the read-out at that concentration, not a potency): 42.3%
Compound 4: middle estimate off by 29.3 percentage points, on the low side, outside the stated range (above it).
By their numbers in this assay, from the lowest: compounds 2, 3 and 1 (each within the scatter of the next, the first and the last beyond it); then compound 4.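

In this assay, going by these compounds alone, hydrogen in place of chloro on an aromatic carbon, para to a large group, gives a number 27.3 percentage points higher from compound 3 to compound 4 (beyond the scatter), which shows that this single position can move the read-out beyond the scatter, something the earlier compounds could not show. The group on the amine nitrogen in the ring also registers now: phenyl in place of (pyridin-2-yl)methyl gives a number 18.9 percentage points higher from compound 1 to compound 4 (beyond the scatter), whereas 4-chlorophenyl in place of the same group gives a number 8.4 percentage points lower from compound 1 to compound 3 (within the scatter), so among these compounds the result of that swap depends on whether the chloro is present. Nothing available explains why the chloro carries this weight.

Still open, from the compounds shown here alone, is whether a fluoro, methyl, methoxy or amino group at this position would read like hydrogen or like chloro, and whether chloro elsewhere on the ring would give the same result. These are also readings at one concentration, so they show a stronger effect of the phenyl compound 4 than of the other compounds at that concentration only, and whether that holds at other concentrations remains unsettled.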